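The compounds below may be only part of what the source reports. "The series", "measured", "known", "first", "only" and "open" are said of these compounds alone.

Measured so far in a functional assay on MIA PaCa-2 cells (Homo sapiens) for antiproliferative activity, read by sulforhodamine B assay, with a stated time of 48 h; on this read-out higher numbers stand for weaker inhibition and lower numbers for stronger inhibition:
- compound 1 `COc1cc(OC)c2sc(-c3ccc(N/C=C\C(=O)c4ccc(OC)c(F)c4)c(C)c3)nc2c1`: 16300 nM
- compound 2 `COc1cc(OC)c2sc(-c3ccc(N/C=C\C(=O)c4ccc(OC)c([N+](=O)[O-])c4)c(C)c3)nc2c1`: 13900 nM
- compound 3 `COc1ccc(C(=O)/C=C\Nc2ccc(-c3nc4cc(OC)c(OC)c(OC)c4s3)cc2)cc1O`: 32800 nM

Compound 1 stands second highest of the three numbers; compound 2 is nearest and compound 3 furthest, both within the scatter. Going by the values given here, the only single-point step recorded, a 1.2-fold lower number from compound 1 to compound 2 (0.07 log units; within the scatter), is a change elsewhere on the molecule and within the scatter.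

Compound 4 `COc1cc(OC)c2sc(-c3ccc(N/C=C\C(=O)c4ccc(OC)c(F)c4)cc3)nc2c1` differs from compound 1 as follows: hydrogen in place of methyl on an aromatic carbon. Among the compounds with values here, no measured step concerns this position. Compound 3 also lacks the methyl but differs in several other places, so its number is only loosely informative. The expected step from compound 1 is a 1.2-fold higher number from compound 1 to compound 4 (0.09 log units; within the scatter), i.e. none beyond the scatter. Compound 4 is therefore estimated at 20000 nM, range 8000 nM to 50000 nM.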

Compound 4, half-maximal inhibitory concentration: 4300 nM
Beside the measured number, compound 4's estimate is 4.7-fold (0.67 log units) above it; measured number below the stated range.
By their numbers in this assay, from the lowest: compound 4; then compounds 2, 1 and 3 (each within the scatter of the next, the first and the last beyond it).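

In this assay, going by these compounds alone, this aromatic carbon, ortho to a large group and meta to a large group, is the first place where a single change moves the number beyond the scatter: a 3.8-fold lower number from compound 1 to compound 4 (0.58 log units; beyond the scatter). The methyl is therefore not needed for activity in this fluoro compound, and hydrogen is the better of the two groups here. Nothing measured on these compounds accounts for the step.

As far as these compounds go, it remains open whether an ethyl group or a chlorine atom on this carbon would track with hydrogen or with methyl. From the compounds shown here alone, it is also open whether the same step would hold with the nitro group of compound 2.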